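This account rests on a few compounds, and the source may have more. Where it says the series, first, only, none or still open, it means among the compounds named here.

Measured so far in a functional assay on CHO cells with Melanocortin receptor 4 (Homo sapiens) as the target, read by cAMP accumulation; a lower number here means a smaller maximal response, a higher number a larger maximal response:
compound 1 `Cc1ccc(N2CCN(C(=O)[C@@H]3CN(C4CCOCC4)C[C@H]3c3ccc(Cl)cc3)CC2)c([C@@H](NC(=O)CN)C(C)C)c1`: 114%
compound 2 `CNCC(=O)N[C@H](c1cc(C)ccc1N1CCN(C(=O)[C@@H]2CN(C3CCOCC3)C[C@H]2c2ccc(Cl)cc2)CC1)C(C)C`: 84%

Compound 2 stands lowest of the two numbers in this assay; its nearest neighbour is compound 1, and the step of a number 30 percentage points lower from compound 1 to compound 2 (beyond the scatter) lies beyond the scatter, brought by a methyl in place of hydrogen on an amine nitrogen.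

Compound 3 `Cc1ccc(N2CCN(C(=O)[C@@H]3CN(C4CCOCC4)C[C@H]3c3ccc(Cl)cc3)CC2)c([C@@H](NC(=O)[C@H](C)N)C(C)C)c1` is still to be measured. It differs from compound 2 in that (1-aminoethyl in place of (methylamino)methyl on a carbonyl carbon). The two have the same atoms joined differently: in compound 3 the amine nitrogen again carries hydrogen, as in compound 1, and the methyl has become part of the 1-aminoethyl group, which also brings one defined stereocentre.

For the measured compounds named here, only the step from compound 1 to compound 2 bears on this change. A rise back toward compound 1 is expected because a number 30 percentage points lower from compound 1 to compound 2 (beyond the scatter) is the only measured effect of that methyl on the nitrogen, with nothing measured on the stereocentre; the expected step is a number 21 percentage points higher from compound 2 to compound 3 (beyond the scatter). Compound 3 is therefore estimated at 105%, within 85% to 125%.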

Compound 3, intrinsic activity: the largest response reached, in percent of the reference agonist's: 38%
The estimate for compound 3 lay 67 percentage points above the measured number, and the stated range ends above it.
By their numbers in this assay, from the lowest: compound 3; then compound 2; then compound 1.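

In this assay, a methyl on the saturated chain carbon bound to an amine nitrogen and a carbonyl carbon brings a large loss of maximal response: a number 76 percentage points lower from compound 1 to compound 3 (beyond the scatter). Compound 2 and compound 3 hold the same atoms joined differently, yet the result is a number 46 percentage points lower from compound 2 to compound 3 (beyond the scatter), so at this position the response depends on where the methyl sits and not merely on its presence. Nothing measured here accounts for the size of this drop.

Whether the loss belongs to the methyl itself or to the configuration of the new stereocentre stays open, since only one configuration of 1-aminoethyl is among the compounds shown. Also open, going by these compounds, is how an ethyl on that chain carbon, or a dimethylamino group in place of the amine, would read in this assay.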